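A few compounds are considered here, and "the series" means these few. Any claim that something is new, unique, unknown or untested is made for them only; others in the source may bear on it.

Measured compounds:
compound 1 `C#CCOC(=O)NN=C1C(Cl)=C(Cl)C(Cl)=C1Cl`: 800 nM
compound 2 `CC(=O)NN=C1C(Cl)=C(Cl)C(Cl)=C1Cl`: 1000 nM

Within the data shown here, in a functional assay on RPMI-8226 cells (Homo sapiens) for cytotoxicity, read by MTT assay, with a stated time of 48 h (on this read-out lower numbers stand for stronger inhibition and higher numbers for weaker inhibition), compound 2 gives 1000 nM, which cannot be told apart from the value of its only measured neighbour, compound 1 at 800 nM. The next compound, compound 3 `ON=C1C(Cl)=C(Cl)C(Cl)=C1Cl`, keeps the shared core but carries hydroxy in place of acetamido on a double-bonded nitrogen.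

Among the measured compounds shown here, only one measured step offers any guide: a 1.3-fold higher number from compound 1 to compound 2 (0.10 log units; within the scatter). That step was methyl in place of propargyloxy on a carbonyl carbon, and it stayed within the scatter. It shows that one swap at the far end of this side chain left this assay essentially unmoved. The coming change is larger, since it removes the carbonyl altogether, so this evidence is thin and the range must stay wide. With nothing pointing firmly either way, no shift beyond the scatter is expected, and the estimated step is a 1.2-fold higher number from compound 2 to compound 3 (0.08 log units; within the scatter). For compound 3 the estimate is 1200 nM, with an expected range from 350 nM to 4000 nM.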

Compound 3, half-maximal inhibitory concentration: > 5000 nM
Compound 3 was reported as a limit (the forecaster's own chance of this, stated with the estimate: 5%); middle value at least 4.1-fold (0.61 log units) from the limit.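

In this assay, swapping the far end of the side chain changed little, but replacing acetamido with hydroxy on the double-bonded nitrogen gives an at least 5.0-fold higher number from compound 2 to compound 3 (0.69 log units; beyond the scatter), so what this nitrogen carries does matter for cytotoxicity in these cells. The value of compound 3, > 5000 nM, is a limit of this assay and not a number, so the step gives only a lower bound on the true change: the limit of > 5000 nM in this assay, at which 1 of the 3 values shown sits. The change removes the whole of acetamido, carbonyl included, in a single move, so compound 2 and compound 3 alone cannot show which part of the side chain counts, although compound 1 and compound 2, which both keep the carbonyl, are the two that read within the scatter of each other.

The compounds shown leave open whether a plain amino group on the double-bonded nitrogen, or a methoxy group in place of hydroxy, would read like compound 2 or like compound 3. They also leave open how a longer chain on the carbonyl would read in this assay.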